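This account rests on a few compounds, and the source may have more. Where it says the series, first, only, none or still open, it means among the compounds named here.

Compound 1 `COc1ccc2nc(C)cc(OCC(=O)Nc3c(C)cccc3C)c2c1` was measured in a physicochemical assay for lipophilicity, read by HPLC, in phosphate buffer, measured as chromatographic lipophilicity, at pH 7.4 (a higher number here means a more lipophilic compound, a lower number a more polar compound), where compound 1 gives 4.55. That is the higher of the two numbers recorded so far; compound 2 `COc1ccc2nc(C)cc(OCC(=O)Nc3cc(OC)c(OC)c(OC)c3)c2c1` gives 3.95 in this assay, a value beyond the scatter below the first. The unmeasured compound 3 `COc1ccc2nc(C)cc(OCC(=O)Nc3noc(C)c3C)c2c1` differs from compound 1 in one place: 4,5-dimethyl-1,2-oxazol-3-yl in place of 2,6-dimethylphenyl on an amide-type nitrogen. For the measured compounds named here, no measured pair shows this exact change, so its size can only be expected: in this assay the step is expected to be downward, by a number 1.25 log units lower from compound 1 to compound 3 (beyond the scatter). Compound 3 is thus estimated at 3.3, within a range from 2.8 to 3.8.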

Compound 3, distribution coefficient: 3.3
Compound 3: middle estimate and measured number agree at the digits printed, and the stated range covers the measured number.
By their numbers in this assay, from the lowest: compound 3; then compound 2; then compound 1.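

On the amide-type nitrogen, in this assay, 4,5-dimethyl-1,2-oxazol-3-yl in place of 2,6-dimethylphenyl gives a number 1.25 log units lower from compound 1 to compound 3 (beyond the scatter), so this position responds strongly to this exchange of one aromatic ring for another. The entering group has 2 hydrogen-bond acceptors and the leaving group 0, but nothing available ties the step to that difference or to any other. Still open, from the compounds shown here alone, is how a plain phenyl or a pyridyl group would read on the same nitrogen, and whether the two methyl groups contribute to the step.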